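Two measured compounds and one to come

A few compounds are considered here, and "the series" means these few. Any claim that something is new, unique, unknown or untested is made for them only; others in the source may bear on it.

Measured so far:
- compound 1, `COc1cc(C)cc(-c2nn(CC#N)cc2-c2ccc(-c3cccc(C(C)=O)c3)nc2)c1`: 19%
- compound 2, `Cc1cc(O)cc(-c2nn(CC#N)cc2-c2ccnc(-c3ccc(Oc4ccccc4)cc3)c2)c1`: -16%

Both compounds were tested in a functional assay on MOLT-4 cells (Homo sapiens) for cytotoxicity, read by sulforhodamine B assay, with a stated time of 48 h, tested at 1 uM; on this read-out higher numbers stand for a weaker effect at the one concentration tested and lower numbers for a stronger effect. On these two numbers compound 2 stands lowest, giving -16%; its nearest neighbour is compound 1, whose value lies higher by an amount beyond the usual scatter. Nothing more can be read from this pair, since the two structures differ in several places at once.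

The next compound, compound 3, `Cc1cc(O)cc(-c2nn(CC#N)cc2-c2ccnc(-c3ccc(N(C)C)cc3)c2)c1`, differs from compound 2 in one place only: dimethylamino in place of phenoxy on an aromatic carbon

Among the measured compounds shown here, no pair of measured compounds that differs in one place is available, so the size of this step cannot be read from earlier data. The expectation is therefore that the step of a number 8 percentage points higher from compound 2 to compound 3 (within the scatter) stays within the scatter, with no clear direction. For compound 3 the estimated value in this assay is -8%, in the range -35% to 20%.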

Compound 3, a percentage reported as activity, at one concentration (the size of the read-out at that concentration, not a potency): 11%
Beside the measured number, compound 3's estimate is 19 percentage points below it; the measured number falls inside the stated range.
By their numbers in this assay, from the lowest: compound 2; then compounds 3 and 1 (each within the scatter of the next).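

Among the compounds shown here, this is the first change at a single place: on an aromatic carbon para to a large group, putting dimethylamino in place of phenoxy gives, in this assay, a number 27 percentage points higher from compound 2 to compound 3 (beyond the scatter) and so a weaker effect at the one concentration tested. The position therefore affects the read-out, and the larger phenoxy, with its six-membered aromatic ring, goes with the stronger effect, although the two groups have the same counts of hydrogen-bond donors and acceptors. Nothing measured here explains the step.

This single step cannot separate the loss of the ring from the exchange of oxygen for nitrogen at the point of attachment. Methoxy, which keeps the oxygen without the ring, and phenylamino, which keeps the ring with a nitrogen, would pull these two changes apart.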